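Aryl amine replacing the amide on the shared core

A few compounds are considered here, and "the series" means these few. Any claim that something is new, unique, unknown or untested is made for them only; others in the source may bear on it.

Compound 3 `CCCC(=O)Nc1nc2ccc(NC(=O)c3c(Cl)cccc3Cl)cc2s1` gives 0.01 ug/mL in a functional assay on WI-38 VA13 cells (Homo sapiens) for cytotoxicity (a lower number here means that less compound is needed, a higher number that more compound is needed for the effect), the lowest number of the three measured; compound 1 `O=C(Nc1ccc2nc(NC(=O)C3CCCCC3)sc2c1)c1cccc(F)c1` gives 0.64 ug/mL and compound 2 `COc1ccc(C(=O)Nc2ccc3nc(NC(=O)C4CCCCC4)sc3c2)cc1` gives 4.9 ug/mL. Compound 4 `COc1ccccc1Nc1nc2ccc(NC(=O)c3c(Cl)cccc3Cl)cc2s1` differs from compound 3 in one place: 2-methoxyphenyl in place of propylcarbonyl on a nitrogen on an aromatic ring. The only measured step, a 7.7-fold higher number from compound 1 to compound 2 (0.88 log units; beyond the scatter), concerns the group on a carbonyl carbon, not the nitrogen on the aromatic ring, so no step shown bears directly on the change from compound 3 to compound 4. With nothing comparable measured, the direction cannot be read from the series; a modest rise is taken as the working expectation, with a wide range. For compound 4 the estimate is 0.1 ug/mL (0.01 ug/mL to 1 ug/mL), which would mean a 10-fold higher number from compound 3 to compound 4 (1.00 log units; beyond the scatter).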

Compound 4, half-maximal effective concentration: > 7.2 ug/mL
Compound 4 gave a limit, no number (the forecaster's own chance of this, stated with the estimate: 5%); at least 72-fold (1.85 log units) between middle value and limit.
By their numbers in this assay, from the lowest: compound 3; then compound 1; then compound 2. At a limit, above all of these: compound 4.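

The nitrogen on the aromatic ring is a sensitive position: in this assay, 2-methoxyphenyl in place of propylcarbonyl gives an at least 720-fold higher number from compound 3 to compound 4 (2.85 log units; beyond the scatter). This step is larger than the change at the group on a carbonyl carbon, a 7.7-fold higher number from compound 1 to compound 2 (0.88 log units; beyond the scatter). The reading for compound 4 is a limit, not a number: the limit of > 7.2 ug/mL in this assay, at which 1 of the 4 values shown sits.

The compounds shown leave open whether the loss of the carbonyl or the arrival of the 2-methoxyphenyl ring carries the step; a benzoyl group on this nitrogen would separate the two. On these data alone, how far compound 4 lies beyond its limit also stays open.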